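The compounds below may be only part of what the source reports. "The series", "measured", "known", "first", "only" and "open" are said of these compounds alone.

Three compounds share one core and differ only in the group on the carbonyl carbon of the amide. Compound 1 `O=C(Nc1ccc(Cl)c(-c2nnc3c(Cl)cccn23)c1)c1ccc(Cl)cc1` carries a 4-chlorophenyl there. In a functional assay on HeLa cells (Homo sapiens) for antiproliferative activity, read by MTT assay, with a stated time of 72 h (on this read-out lower numbers stand for stronger inhibition and higher numbers for weaker inhibition), compound 1 gives only a limit, > 100000 nM, not a number. Compound 2 `O=C(Nc1ccc(Cl)c(-c2nnc3c(Cl)cccn23)c1)c1ccc(Cl)cc1Cl` carries a 2,4-dichlorophenyl there. In this assay compound 2 also gives only a limit, > 100000 nM. Compound 3 `O=C(Nc1ccc(Cl)c(-c2nnc3c(Cl)cccn23)c1)c1ccon1` carries a 1,2-oxazol-3-yl there. In this assay compound 3 likewise gives only a limit, > 100000 nM. Compound 3 therefore stands where the other two stand, at the limit of > 100000 nM in this assay, at which 3 of the 3 values shown sit, with no number that would set it apart. The steps between the measured compounds are all unreadable: a step that the two limits leave unreadable from compound 1 to compound 2, a step that the two limits leave unreadable from compound 1 to compound 3 and a step that the two limits leave unreadable from compound 2 to compound 3.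

Compound 4 `O=C(Nc1ccc(Cl)c(-c2nnc3c(Cl)cccn23)c1)c1cccnc1Cl` differs from compound 3 in one place: 2-chloropyridin-3-yl in place of 1,2-oxazol-3-yl on a carbonyl carbon. Among the compounds with values here, the steps that bear on this exchange of the acyl group are the two that reach compound 3, a step that the two limits leave unreadable from compound 1 to compound 3 and a step that the two limits leave unreadable from compound 2 to compound 3, and both have no readable size or direction. The expected step of a number no higher from compound 3 to compound 4 (the limit leaves the size open) is accordingly one that cannot be read either, because each exchange so far has left the value at the limit of > 100000 nM in this assay, at which 3 of the 3 values shown sit. Compound 4 is expected to give 100000 nM in this assay, within a range from 30000 nM to 300000 nM, and most likely again only as a limit.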

Compound 4, half-maximal inhibitory concentration: 87500 nM
Beside the measured number, compound 4's estimate is 1.1-fold (0.06 log units) above it; the range from low to high includes it.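

In this assay, within the data shown here, compound 4 is the first compound here to give a number rather than a limit, 87500 nM, so a readable value can be obtained with 2-chloropyridin-3-yl on the carbonyl carbon. The exchanges now read as an at least 1.1-fold lower number from compound 3 to compound 4 (0.05 log units; that floor lies within the scatter), an at least 1.1-fold lower number from compound 2 to compound 4 (0.05 log units; that floor lies within the scatter) and an at least 1.1-fold lower number from compound 1 to compound 4 (0.05 log units; that floor lies within the scatter), which gives each step a direction and a floor for its size, though that floor alone does not set compound 4 apart from the other compounds. The steps among compound 1, compound 2 and compound 3 still cannot be read, and the values of these compounds remain limits: the limit of > 100000 nM in this assay, at which 3 of the 4 values shown sit.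

The compounds shown leave open how large the three steps really are, and whether the chlorine or the ring nitrogen of the 2-chloropyridin-3-yl matters more for the readable value. They also do not tell what a pyridin-3-yl without the chlorine, or a longer chain on the carbonyl carbon, would give in this assay.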